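Swapping an Arylsulfonyl Group for a Triazolylmethyl Group

This account rests on a few compounds, and the source may have more. Where it says the series, first, only, none or still open, it means among the compounds named here.

Compound 1 `CNC(=O)c1cccc(S(=O)(=O)c2ccccc2Cc2c3c(n(CC(=O)O)c2C)CCNC3=O)c1`: 240 nM
Compound 2 `Cc1c(Cc2ccccc2S(=O)(=O)c2ccc(F)cc2)c2c(n1CC(=O)O)CCNC2=O`: 3.3 nM

Both were tested in a functional assay on CHO.K1 cells for antagonist activity at prostaglandin D2 receptor 2 (Homo sapiens), read by GTPgammaS binding, with a stated time of 1 h; a higher number here means a weaker inhibitor, a lower number a stronger inhibitor. Compound 2 gives the lower of the two numbers, and the gap to compound 1, a 73-fold lower number from compound 1 to compound 2 (1.86 log units; beyond the scatter), lies beyond the scatter, so compound 2 is the stronger inhibitor of the pair. Compound 3 `Cc1c(Cc2ccccc2Cn2ccnn2)c2c(n1CC(=O)O)CCNC2=O` has not yet been measured. It differs from compound 2 in one place: (1H-1,2,3-triazol-1-yl)methyl in place of (4-fluorophenyl)sulfonyl on an aromatic carbon. For the measured compounds named here, only one measured step bears on this region: it exchanged just the aryl group on the sulfonyl sulfur and still moved the number a great deal. Here the whole sulfonyl group leaves, a larger change for which no measured pair exists. Because this region already produced a 73-fold lower number from compound 1 to compound 2 (1.86 log units; beyond the scatter), a large shift is expected, most likely toward a weaker inhibitor. Compound 3 is therefore estimated at 150 nM, within 15 nM to 1500 nM. This estimate is expected to correspond to a 45-fold higher number from compound 2 to compound 3 (1.66 log units; beyond the scatter).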

Compound 3, half-maximal inhibitory concentration: 800 nM
For compound 3 the middle estimate is 5.3-fold (0.73 log units) below the measured one, and the stated range covers the measured number.
By their numbers in this assay, from the lowest: compound 2; then compound 1; then compound 3.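

In this assay, the earlier step changed only the aryl group on the sulfonyl sulfur, whereas this one removes the whole (4-fluorophenyl)sulfonyl group and gives a 240-fold higher number from compound 2 to compound 3 (2.38 log units; beyond the scatter). So this position responds strongly not only to which aryl group the sulfonyl carries, but also to replacing the sulfonyl group and its ring together with (1H-1,2,3-triazol-1-yl)methyl, which has fewer heavy atoms. No measurement available here explains why the number rises so far.

Still open, on these data alone, is whether the sulfonyl link or the aromatic ring it carries matters more for the low number of compound 2. A methylsulfonyl group, which keeps the sulfonyl without the ring, and a benzyl group, which keeps a ring without the sulfonyl, would help separate the two.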